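Aryl variation on the hydrazone carbon: toward compound 4

The source may report more compounds than this note shows. Statements on the series, on what has been measured and on what is new or still open speak of the compounds shown alone.

In a functional assay on ECa-109 cells (Homo sapiens) for antiproliferative activity, read by MTT assay, with a stated time of 72 h (on this read-out lower numbers stand for stronger inhibition and higher numbers for weaker inhibition), compound 1 `CCCSc1nc(N/N=C/c2ccccc2Cl)c2nnn(Cc3ccccc3)c2n1` gives 6180 nM, compound 2 `CCCSc1nc(N/N=C/c2ccc(N(C)C)cc2)c2nnn(Cc3ccccc3)c2n1` gives 20000 nM and compound 3 `CCCSc1nc(N/N=C/c2c(O)ccc3ccccc23)c2nnn(Cc3ccccc3)c2n1` gives 9290 nM. Compound 3 stands second highest of the three numbers: the step of a 1.5-fold higher number from compound 1 to compound 3 (0.18 log units; within the scatter) lies within the scatter, while a 2.2-fold lower number from compound 2 to compound 3 (0.33 log units; beyond the scatter) is modest. Compound 4 `CCCSc1nc(N/N=C/c2ccc3ccccc3c2)c2nnn(Cc3ccccc3)c2n1` differs from compound 3 by naphthalen-2-yl in place of 2-hydroxynaphthalen-1-yl on a carbon with a double bond to nitrogen. Among the compounds with values here, no measured step brings in naphthalen-2-yl; the steps that bear on the change are the two that bring in 2-hydroxynaphthalen-1-yl, a 1.5-fold higher number from compound 1 to compound 3 (0.18 log units; within the scatter) and a 2.2-fold lower number from compound 2 to compound 3 (0.33 log units; beyond the scatter), both small. The expected step is therefore a 1.3-fold lower number from compound 3 to compound 4 (0.12 log units; within the scatter), with no direction beyond the scatter. Compound 4 is expected to give 7000 nM in this assay, estimated between 3000 nM and 16000 nM.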

Compound 4, half-maximal inhibitory concentration: > 64000 nM
Compound 4: only a limit was reported; the forecaster's own chance of this, stated with the estimate: 5%; middle value at least 9.1-fold (0.96 log units) away from the limit.
By their numbers in this assay, from the lowest: compounds 1 and 3 (each within the scatter of the next); then compound 2. At a limit, above all of these: compound 4.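

In this assay the reading for compound 4 is a limit and not a number: the limit of > 64000 nM in this assay, at which 1 of the 4 values shown sits. This place on the carbon with a double bond to nitrogen can therefore move the read-out much further than compounds 1 to 3 showed, with an at least 6.8-fold higher number from compound 3 to compound 4 (0.83 log units; beyond the scatter) and an at least 3.2-fold higher number from compound 2 to compound 4 (0.50 log units; beyond the scatter) and an at least 10-fold higher number from compound 1 to compound 4 (1.01 log units; beyond the scatter). Compounds 3 and 4 both carry 2 six-membered aromatic rings of carbon only, so that ring count alone does not hold the read-out.

The change from compound 3 to compound 4 moves the ring attachment and removes the hydroxy group together, and the compounds shown do not separate the two. Naphthalen-1-yl, without the hydroxy group, would bear on that question.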